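The source may report more compounds than this note shows. Statements on the series, on what has been measured and on what is new or still open speak of the compounds shown alone.

Measured so far in an assay for inhibition of MAP kinase-interacting serine/threonine-protein kinase 2 (Homo sapiens), read by luminescence and ADP-Glo, with a stated time of 2 h; on this read-out lower numbers stand for stronger inhibition and higher numbers for weaker inhibition:
- compound 1, `Nc1n[nH]c2cc(-c3ccc(=O)n(Cc4ccccc4)c3)ccc12`: 32 nM
- compound 2, `NC(=O)c1ccc(Cn2cc(-c3ccc4cn[nH]c4c3)ccc2=O)cc1`: > 2000 nM

Going by the values given here, compound 1 holds the only numerical value in this assay. Compound 2 returns a limit of the assay, not a number, the reading of the limit of > 2000 nM in this assay, at which 1 of the 2 values shown sits. Compound 3, `Nc1n[nH]c2cc(-c3ccc(=O)n(Cc4cccc(Cl)c4)c3)ccc12`, is not yet measured; it differs from compound 1 by chloro in place of hydrogen on an aromatic carbon. Among the compounds with values here, no measured step of this kind exists, so the expected step is small, with no clear direction beyond the scatter. For compound 3 the expected value in this assay is 28 nM, within 9 nM to 90 nM, an expected step of a 1.1-fold lower number from compound 1 to compound 3 (0.06 log units; within the scatter).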

Compound 3, half-maximal inhibitory concentration: 6 nM
Estimate against measurement, compound 3: 4.7-fold (0.67 log units) above; the whole stated range lies above it.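

In this assay, going by these compounds alone, the change from benzyl to 3-chlorobenzyl gives a 5.3-fold lower number from compound 1 to compound 3 (0.73 log units; beyond the scatter) as the first measured step on this ring. The aromatic carbon meta to a large group therefore accepts a chlorine, and the step lies beyond the scatter. Nothing shown here gives a cause for this step.

One substituent at one place cannot show whether the step is particular to chloro or to this position. Fluoro, methyl, methoxy, an amine or a carboxylic acid at the same carbon remain open, as does chloro elsewhere on the ring.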